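A few compounds are considered here, and "the series" means these few. Any claim that something is new, unique, unknown or untested is made for them only; others in the source may bear on it.

Compounds 1, 2 and 3 share one core. Compound 1 `COc1ccc(/C=C/C2CC(=O)C=CO2)cc1` and compound 2 `COc1ccc(C2CC(=O)C=CO2)cc1` differ in how the outer ring is attached; in a functional assay on HT-29 cells (Homo sapiens) for inhibition, read by sulforhodamine B assay, with a stated time of 48 h (a higher number here means a weaker inhibitor of growth, a lower number a stronger inhibitor of growth), compound 1 gives 204 uM and compound 2 gives 203 uM, two numbers that sit within the scatter of each other. Compound 3 `COc1ccc(C2CC(=O)C(Br)=CO2)cc1` gives 69 uM, the lowest of the three numbers, and the step of a 2.9-fold lower number from compound 2 to compound 3 (0.47 log units; beyond the scatter) lies beyond the scatter. Compound 4 `COc1ccc(C2CC(=O)C(I)=CO2)cc1` carries the change (iodo in place of bromo on a double-bonded ring carbon). Going by the values given here, no measured step exchanges one halogen for another; the only step at this position is the hydrogen-to-bromo step just described, which was modest. The estimate is therefore a small step, a 1.4-fold lower number from compound 3 to compound 4 (0.14 log units; within the scatter), likely within the scatter. Compound 4 is expected at 50 uM, in the range 20 uM to 150 uM.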

Compound 4, concentration for growth inhibition (reported as GI): 24.4 uM
For compound 4 the middle estimate is 2.0-fold (0.31 log units) above the measured one; low and high end bracket the measured number.
By their numbers in this assay, from the lowest: compound 4; then compound 3; then compounds 2 and 1 (each within the scatter of the next).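

The position responds to which halogen it carries, not only to whether one is present: in this assay the change from bromo to iodo gives a 2.8-fold lower number from compound 3 to compound 4 (0.45 log units; beyond the scatter) on the same double-bonded ring carbon. Measured against hydrogen, iodo gives an 8.3-fold lower number from compound 2 to compound 4 (0.92 log units; beyond the scatter), so the numbers fall from hydrogen through bromo to iodo across compounds 2, 3 and 4. Nothing available explains this trend.

Still open, as far as these compounds go, is how chloro, or a non-halogen such as a nitrile or a methyl, would behave at this carbon. From the compounds shown here alone, whether iodo would give a similar step on the core of compound 1 also remains unknown.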